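The source may hold more compounds than are shown below. What is called first, only, known or untested is meant among the compounds shown, and "the series" means these compounds.

In a functional assay on K562 cells (Homo sapiens), read by MTT assay, with a stated time of 72 h (on this read-out lower numbers stand for stronger inhibition and higher numbers for weaker inhibition), compound 1 (`CNc1ncnc2c1c(-c1ccco1)cn2[C@@H]1O[C@H](CO)[C@@H](O)[C@H]1O`) gives 220 nM. Compound 2 (`CNc1ncnc2c1c(-c1ccoc1)cn2[C@@H]1O[C@H](CO)[C@@H](O)[C@H]1O`) gives > 20000 nM, which is a limit. Compound 3 (`C#Cc1cn([C@@H]2O[C@H](CO)[C@@H](O)[C@H]2O)c2ncnc(NC)c12`) gives > 20000 nM, again only a limit, which is the limit of > 20000 nM in this assay, at which 2 of the 3 values shown sit. Compound 4 (`CNc1ncnc2c1c(I)cn2[C@@H]1O[C@H](CO)[C@@H](O)[C@H]1O`) carries iodo in place of ethynyl on an aromatic carbon. The measured steps at this carbon are an at least 90-fold higher number from compound 1 to compound 2 (1.95 log units; beyond the scatter) and an at least 90-fold higher number from compound 1 to compound 3 (1.95 log units; beyond the scatter), both large, but neither involves iodo. Only compound 1 has left the limit, so compound 4 is expected to stay near it, with at most a modest fall in this assay. The expected step is an at least 2.5-fold lower number from compound 3 to compound 4 (0.39 log units; beyond the scatter). For compound 4 the estimated value is 8000 nM, with an expected range of 800 nM to 20000 nM.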

Compound 4, half-maximal inhibitory concentration: > 100000 nM
Compound 4 gave a limit, no number; the forecaster's own chance of this, stated with the estimate: 45%; middle value at least 12-fold (1.09 log units) from the limit.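

In this assay, replacing furan-2-yl with iodo on this aromatic carbon gives an at least 450-fold higher number from compound 1 to compound 4 (2.65 log units; beyond the scatter). Compound 4 sits at a limit, > 100000 nM, so iodo joins furan-3-yl and ethynyl among the groups without a readable number, and furan-2-yl in compound 1 is the only one of the four that has one. The steps among compound 2, compound 3 and compound 4 cannot be read, so these three groups cannot be ranked. On these data alone, it remains open whether furan-2-yl is unusual here or whether phenyl or thiophen-2-yl on this carbon would also give a number.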